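The compounds below may be only part of what the source reports. "The series", "measured", "known", "first", "only" and "open" are said of these compounds alone.

Of the compounds shown here, three sharing one core have been read in an in vitro ADME assay on microsomes from liver (Homo sapiens) for metabolic stability, with a stated time of 15 min; on this read-out higher numbers stand for fast clearance and lower numbers for slow clearance: compound 1 (`CCc1nn2c(-c3cc(OC)c(OC)cc3OC)cccc2c1N(CC1CCOCC1)CC1CC1`) gives 600 mL.min-1.g-1, compound 2 (`CCc1nn2c(-c3c(COC)cc(OC)cc3OC)cccc2c1N(CC1CCOCC1)CC1CC1`) gives 530 mL.min-1.g-1 and compound 3 (`CCc1nn2c(-c3c(C)cc(OC)cc3OC)cccc2c1N(CC1CCOCC1)CC1CC1`) gives 450 mL.min-1.g-1. Compound 3 thus stands within the scatter of both others. Compound 4 (`CCc1nn2c(-c3c(C)cc(C)cc3OC)cccc2c1N(CC1CCOCC1)CC1CC1`) differs from it by methyl in place of methoxy on an aromatic carbon, para to a large group: methyl in place of methoxy on an aromatic carbon. Going by the values given here, no measured step makes this exchange. Among the compounds with values here, the only step available, a 1.2-fold lower number from compound 2 to compound 3 (0.07 log units; within the scatter), concerns a saturated chain carbon and stayed within the scatter. On that slim basis, no step beyond the scatter is expected in this assay. The expected step is a 1.0-fold lower number from compound 3 to compound 4 (0.02 log units; within the scatter). For compound 4 the estimated number is 430 mL.min-1.g-1, with an expected range of 240 mL.min-1.g-1 to 760 mL.min-1.g-1.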

Compound 4, intrinsic clearance in microsomes: 450 mL.min-1.g-1
Estimate against measurement, compound 4: 1.0-fold (0.02 log units) below; the measured number falls inside the stated range.
By their numbers in this assay, from the lowest: compounds 3, 4, 2 and 1 (each within the scatter of the next).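

At this position, para to a large group, this assay now gives a direct reading of an exchange on an aromatic carbon: methyl in place of methoxy yields no change at the digits printed from compound 3 to compound 4 (within the scatter). Going by these compounds alone, the only earlier step concerned a saturated chain carbon, so this is the first sign that removing the methoxy oxygen from the aromatic ring leaves the read-out within the scatter. Nothing shown accounts for this result. Open, going by these compounds, is whether an amine, a carboxylic acid or a longer chain at this position would also stay within the scatter.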